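From 3-chlorophenyl to 2-nitrophenyl on a shared core

The source may hold more compounds than are shown below. What is called first, only, known or untested is meant among the compounds shown, and "the series" means these compounds.

In a functional assay on MCF7 cells (Homo sapiens) for cytotoxicity, read by MTT assay, with a stated time of 96 h (a lower number here means a stronger inhibitor, a higher number a weaker inhibitor), compound 1 (`COc1cc(C(=O)c2cn(-c3cccc(Br)c3)cc2-c2ccccc2)cc(OC)c1OC`) gives 78 nM. Compound 2 (`COc1cc(C(=O)c2cn(-c3ccccc3)cc2-c2cccc(Cl)c2)cc(OC)c1OC`) gives 540 nM, the higher of the two numbers and therefore the weaker result, and the gap between them lies beyond the usual scatter of repeated measurements. These two compounds differ in more than one place, so their gap cannot be assigned to any single group.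

Compound 3 (`COc1cc(C(=O)c2cn(-c3ccccc3)cc2-c2ccccc2[N+](=O)[O-])cc(OC)c1OC`) has not yet been measured. It keeps the rest of compound 2 but carries 2-nitrophenyl in place of 3-chlorophenyl on an aromatic carbon of a five-membered aromatic ring with 1 nitrogen (2-nitrophenyl in place of 3-chlorophenyl on an aromatic carbon). Among the measured compounds shown here, no measured pair shows this exchange on its own, so the data offer no direct guide and any forecast is uncertain. The expected step, a 1.7-fold higher number from compound 2 to compound 3 (0.22 log units; within the scatter), is small, points towards a weaker result and stays within the scatter. Compound 3 is estimated at 900 nM, with an expected range from 150 nM to 4000 nM.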

Compound 3, half-maximal inhibitory concentration: 49 nM
Beside the measured number, compound 3's estimate is 18-fold (1.26 log units) above it, outside the stated range (below it).
By their numbers in this assay, from the lowest: compounds 3 and 1 (each within the scatter of the next); then compound 2.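

The exchange on this aromatic carbon of the five-membered ring is not a neutral one: in this assay, replacing 3-chlorophenyl with 2-nitrophenyl gives an 11-fold lower number from compound 2 to compound 3 (1.04 log units; beyond the scatter), a large step well beyond the scatter. Among the compounds shown here, this is the first comparison that isolates a single place, so it shows that the substituent on this phenyl group can strongly affect the result, and that a nitro group named at the 2 position is compatible with a strong result on this core. The step combines several changes, however: chlorine gives way to nitro, the number in the group's name moves from 3 to 2, and the counts shift to 9 heavy atoms from 7 and to 2 hydrogen-bond acceptors from 0.

Separating the group from its location would take matched comparisons with 2-chlorophenyl and 3-nitrophenyl, while an amine such as 2-aminophenyl would show whether the nitro group can be replaced at all. Nothing available here accounts for the size of this step.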